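The compounds below may be only part of what the source reports. "The series", "measured", "known", "first", "only" and "open" are said of these compounds alone.

Of the compounds shown here, three of a shared core have been measured in a functional assay on HeLa cells (Homo sapiens) for inhibition, read by sulforhodamine B assay, with a stated time of 48 h; on this read-out lower numbers stand for stronger inhibition of growth and higher numbers for weaker inhibition of growth. Compound 1 `COC(=O)[C@@]1(C)CC[C@@H]2C3=C1CC[C@@H](C)[C@]3(C)C[C@@H]1c3cc(Cl)ccc3N[C@H]21` gives 23000 nM in this assay. Compound 2 `COC(=O)[C@@]1(C)CC[C@@H]2C3=C1CC[C@@H](C)[C@]3(C)Cc1c2[nH]c2ccccc12` gives 3200 nM. Compound 3 `COC(=O)[C@@]1(C)CC[C@@H]2C3=C1CC[C@@H](C)[C@]3(C)Cc1c2[nH]c2ccc(C)cc12` gives 11000 nM, which places it second highest of the three numbers: compound 2 sits well below it, and compound 1 above it. The only single-point step among these is a 3.4-fold higher number from compound 2 to compound 3 (0.54 log units; beyond the scatter).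

Compound 4 `COC(=O)[C@@]1(C)CC[C@@H]2C3=C1CC[C@@H](C)[C@]3(C)Cc1c2[nH]c2ccc(Br)cc12` is the next member. It differs from compound 3 by bromo in place of methyl on an aromatic carbon. Among the compounds with values here, no measured pair shows a bromo entering in place of a methyl on this core, and compound 1 carries its chloro on a different core, so its value cannot be turned into a step for this change. Within the data shown here, the one step that touches the same position, from hydrogen to methyl between compound 2 and compound 3, was modest, and bromo and methyl each count one heavy atom with no change in donors, acceptors or charge. The expectation for compound 4 is therefore a step of a 1.1-fold higher number from compound 3 to compound 4 (0.04 log units; within the scatter) in this assay, which is within the scatter. Compound 4 is estimated at 12000 nM, with a range from 5000 nM to 30000 nM.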

Compound 4, concentration for 50% growth inhibition: 14000 nM
Beside the measured number, compound 4's estimate is 1.2-fold (0.07 log units) below it; the range from low to high includes it.
By their numbers in this assay, from the lowest: compound 2; then compounds 3, 4 and 1 (each within the scatter of the next, the first and the last beyond it).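

Bromo in place of methyl on this aromatic carbon gives a 1.3-fold higher number from compound 3 to compound 4 (0.10 log units; within the scatter) in this assay, so the two groups cannot be told apart here, something the hydrogen-to-methyl step alone could not show. Set against the hydrogen of compound 2, bromo gives a 4.4-fold higher number from compound 2 to compound 4 (0.64 log units; beyond the scatter), a step of the same direction as a 3.4-fold higher number from compound 2 to compound 3 (0.54 log units; beyond the scatter), so among these three compounds the weaker inhibition of growth is not confined to methyl: both groups on this carbon, which is meta to one fused ring and para to another, stand apart from hydrogen. Nothing available explains why methyl and bromo give such similar numbers on the shared core.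

The compounds shown leave open whether any group at this place can match or improve on hydrogen, for instance a hydroxyl, an amine, a carboxylic acid or a longer chain, since only methyl and bromo are compared with it here. Within the data shown here, they also leave open how the chloro of compound 1 would act on the core of compound 2, since compound 1 differs from the others in more than one place and gives no step for that change.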